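The source may report more compounds than this note shows. Statements on the series, on what has been measured and on what is new or still open speak of the compounds shown alone.

Compound 3 `O=S(=O)(Nc1ccc2oc(-c3ccccc3)nc2c1)c1cccc(Cl)c1` is measured in an ADME assay on HEK293 cells (Homo sapiens) for cytotoxicity, read by resazurin assay, with a stated time of 48 h (on this read-out lower numbers stand for higher toxicity in this test and higher numbers for lower toxicity in this test), at 70000 nM. Of the two numbers shown, its number is the highest, yet the gap is a 1.1-fold higher number from compound 2 to compound 3 (0.05 log units; within the scatter), within the scatter. Compound 2 `COc1cccc(S(=O)(=O)Nc2ccc3oc(-c4ccccc4)nc3c2)c1` gives 63000 nM in this assay. Compound 1 `O=S(=O)(Nc1ccc2oc(-c3ccccc3)nc2c1)c1cccc(C(F)(F)F)c1` shows only a limit, > 100000 nM, which is the limit of > 100000 nM in this assay, at which 1 of the 3 values shown sits. The move to compound 4 `O=S(=O)(Nc1ccc2oc(-c3ccccc3)nc2c1)c1ccc(Cl)c(Cl)c1` is chloro in place of hydrogen on an aromatic carbon. The measured steps, an at least 1.5-fold lower number from compound 1 to compound 2 (0.20 log units; that floor lies within the scatter) and an at least 1.4-fold lower number from compound 1 to compound 3 (0.15 log units; that floor lies within the scatter), each swap one group for another on an aromatic carbon and lie within the scatter; none puts chloro in place of hydrogen, so none bears directly on this move. The expected step is a 1.4-fold lower number from compound 3 to compound 4 (0.15 log units; within the scatter), within the scatter. Compound 4 is estimated at 50000 nM, between 15000 nM and 150000 nM.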

Compound 4, half-maximal cytotoxic concentration: 71000 nM
The estimate for compound 4 lay 1.4-fold (0.15 log units) below the measured number; low and high end bracket the measured number.
By their numbers in this assay, from the lowest: compounds 2, 3 and 4 (each within the scatter of the next). At a limit, above all of these: compound 1.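

In this assay, the first change shown at this position, ortho to a chloro group and para to a large group, is chloro in place of hydrogen, and it gives a 1.0-fold higher number from compound 3 to compound 4 (0.01 log units; within the scatter). Swapping the whole ring substituent pattern, 3,4-dichlorophenyl in place of 3-methoxyphenyl, likewise gives a 1.1-fold higher number from compound 2 to compound 4 (0.05 log units; within the scatter). Nothing measured here offers a reason for these readings. As far as these compounds go, whether an amine, a carboxylic acid or a longer chain at this position would read differently stays open, as does whether chloro here behaves the same without the other chloro on the ring.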